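The source may report more compounds than this note shows. Statements on the series, on what has been measured and on what is new or still open speak of the compounds shown alone.

Measured values in a functional assay on MCF7 cells (Homo sapiens) for antiproliferative activity, read by MTT assay, with a stated time of 48 h; a higher number here means a weaker inhibitor, a lower number a stronger inhibitor:

Compound 1 `O=Cc1cn(-c2ccccc2)nc1-c1ccc(Cl)cc1`: 9650 nM
Compound 2 `Fc1ccc2[nH]c(-c3cn(-c4ccccc4)nc3-c3ccccc3)nc2c1`: 2430 nM
Compound 3 `Cc1ccc2[nH]c(-c3cn(-c4ccccc4)nc3-c3ccccc3)nc2c1`: 5940 nM

Compound 2 gives the lowest number of the three, so it is the strongest inhibitor here. Compound 3, which carries a methyl in place of fluoro on an aromatic carbon, shows a 2.4-fold higher number from compound 2 to compound 3 (0.39 log units; beyond the scatter). Compound 1, with a different core, gives a higher number than either.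

Compound 4 `FC(F)(F)c1ccc2[nH]c(-c3cn(-c4ccccc4)nc3-c3ccccc3)nc2c1` differs from compound 2 by trifluoromethyl in place of fluoro on an aromatic carbon. For the measured compounds named here, the only measured step that bears on this is the one from compound 2 to compound 3, where a methyl replaced the fluoro and the number rose modestly. Trifluoromethyl also replaces fluoro, so a modest rise is expected, a 2.1-fold higher number from compound 2 to compound 4 (0.31 log units; beyond the scatter). Compound 4 is therefore estimated at 5000 nM, within 2000 nM to 12000 nM.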

Compound 4, half-maximal inhibitory concentration: 2660 nM
Compound 4: middle estimate off by 1.9-fold (0.27 log units), on the high side; measured number inside the range.
By their numbers in this assay, from the lowest: compounds 2 and 4 (each within the scatter of the next); then compounds 3 and 1 (each within the scatter of the next).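

Fluoro and trifluoromethyl on this aromatic carbon give numbers that cannot be told apart (a 1.1-fold higher number from compound 2 to compound 4 (0.04 log units; within the scatter)). Trifluoromethyl and methyl, by contrast, can be told apart (a 2.2-fold lower number from compound 3 to compound 4 (0.35 log units; beyond the scatter)), so among these three groups, the one with more heavy atoms does not give a higher number than fluoro. No measurement of any property of these groups is available to account for this difference.

From the compounds shown here alone, whether an amine, a carboxylic acid or a longer chain at this position would give a number like that of compound 2 stays open. So does whether trifluoromethyl would match fluoro on another ring of the shared core.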